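This account rests on a few compounds, and the source may have more. Where it says the series, first, only, none or still open, it means among the compounds named here.

Working notes on the series in an assay on isolated protein for antagonist activity at Bile acid receptor (Homo sapiens), read by TR-FRET, with a stated time of 20 min; a lower number here means a stronger inhibitor, a higher number a weaker inhibitor. Compound 3 `COc1cccc(Cn2cc(C(=O)Nc3ccc(C)c(S(=O)(=O)N4CCOCC4)c3)c(-c3cccc(OC)c3)n2)c1` gives 42.8 nM and holds the lowest number of the three measured compounds. Compound 1 `COc1cccc(Cn2cc(C(=O)Nc3ccc(C)c(S(=O)(=O)N4CCOCC4)c3)c(C(C)C)n2)c1` gives 199 nM and compound 2 `COc1cccc(-c2nn(C(C)C)cc2C(=O)Nc2ccc(C)c(S(=O)(=O)N3CCOCC3)c2)c1` gives 160 nM in this assay. The two measured steps, a 4.6-fold lower number from compound 1 to compound 3 (0.67 log units; beyond the scatter) and a 3.7-fold lower number from compound 2 to compound 3 (0.57 log units; beyond the scatter), both concern substituents on the core rings. Compound 4 `COc1cccc(Cn2cc(C(=O)N(C)c3ccc(C)c(S(=O)(=O)N4CCOCC4)c3)c(-c3cccc(OC)c3)n2)c1` differs from compound 3 by methyl in place of hydrogen on an amide-type nitrogen. Among the measured compounds shown here, no measured step touches the amide nitrogen, so the two known steps do not bear directly on this change; they only show that the series tolerates modest shifts. For compound 4 a modest rise in this assay, a 3.5-fold higher number from compound 3 to compound 4 (0.54 log units; beyond the scatter), is expected. Compound 4 is estimated at 150 nM, within 40 nM to 600 nM.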

Compound 4, half-maximal inhibitory concentration: 3810 nM
For compound 4 the middle estimate is 25-fold (1.40 log units) below the measured one; measured number outside the range, above it.
By their numbers in this assay, from the lowest: compound 3; then compounds 2 and 1 (each within the scatter of the next); then compound 4.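

In this assay, among the compounds shown here, the amide-type nitrogen proves far less forgiving than the substituent positions on the core: methyl in place of hydrogen, a change of one heavy atom, gives an 89-fold higher number from compound 3 to compound 4 (1.95 log units; beyond the scatter), the only large step. The amide hydrogen therefore matters more to this number than either earlier change suggested. Nothing measured here accounts for the rise.

Still open, as far as these compounds go, is whether an ethyl group or a longer chain on this nitrogen behaves like methyl. The compounds shown also leave open whether the same change has a similar effect with isopropyl on the core.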